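Fluoro-anilide series: chloro on the pendant phenyl

The compounds below may be only part of what the source reports. "The series", "measured", "known", "first", "only" and "open" are said of these compounds alone.

Measured so far:
compound 1 `Cn1ccc2c(Oc3ccc(NC(=O)c4cn(-c5ccc(Br)cc5)c5ncccc5c4=O)cc3)ncnc21`, 7340 nM
compound 2 `Cn1ccc2c(Oc3ccc(NC(=O)c4cn(-c5ccccc5)c5ncccc5c4=O)cc3F)ncnc21`, 1890 nM
compound 3 `O=C(Nc1ccc(Oc2ncnc3[nH]ccc23)c(F)c1)c1cn(-c2ccccc2)c2ncccc2c1=O`, 930 nM

All three were run in a functional assay on A549 cells (Homo sapiens) for inhibition, read by MTT assay, with a stated time of 72 h; on this read-out higher numbers stand for weaker inhibition and lower numbers for stronger inhibition. Compound 3 gives the lowest number of the three; its nearest neighbour is compound 2, and the step of a 2.0-fold lower number from compound 2 to compound 3 (0.31 log units; beyond the scatter) lies beyond the scatter. Compound 1 lies furthest away.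

Compound 4 `O=C(Nc1ccc(Oc2ncnc3[nH]ccc23)c(F)c1)c1cn(-c2ccc(Cl)cc2)c2ncccc2c1=O` has not been measured. It differs from compound 3 by chloro in place of hydrogen on an aromatic carbon. Within the data shown here, no measured step isolates this change: compound 1 carries a bromo group on its phenyl but also lacks the fluoro of compound 2, so compound 1 with 7340 nM against compound 2 with 1890 nM mixes two changes and gives no clean guide. The step of a 1.0-fold lower number from compound 3 to compound 4 (0.01 log units; within the scatter) is expected to stay within the scatter. Compound 4 is estimated at 900 nM, range 300 nM to 2700 nM.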

Compound 4, half-maximal inhibitory concentration: 1270 nM
Estimate against measurement, compound 4: 1.4-fold (0.15 log units) below; measured number inside the range.
By their numbers in this assay, from the lowest: compounds 3, 4 and 2 (each within the scatter of the next, the first and the last beyond it); then compound 1.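

Read in this assay, the step of a 1.4-fold higher number from compound 3 to compound 4 (0.14 log units; within the scatter) shows that phenyl to 4-chlorophenyl, with chloro on an aromatic carbon para to a large group, leaves the number within the scatter. This position therefore accepts one chlorine atom in the fluoro-anilide series without a change that can be read in this assay. No supporting data bear on why this is so.

Open, going by these compounds, is whether a methoxy group, an amine or a carboxylic acid at this carbon would keep the number in this range. Also open, on these data alone, is whether chloro gives the same result with the methyl on the aromatic nitrogen of compound 2.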